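This account rests on a few compounds, and the source may have more. Where it says the series, first, only, none or still open, it means among the compounds named here.

Of the compounds shown here, three built on one shared core have been tested in an in vitro assay on CHO cells for displacement of a labelled ligand from Bombesin receptor subtype-3 (Homo sapiens), read by scintillation counting, with a stated time of 2 h; a lower number here means a stronger inhibitor, a higher number a weaker inhibitor. Compound 1 `CCC(C)(C)Cc1c[nH]c(CCc2ccc(-c3cccc(N)n3)cc2)n1` gives 7.3 nM, compound 3 `CCC(C)(C)Cc1c[nH]c(CCc2ccc(-c3cccnc3)cc2)n1` gives 7.5 nM, and compound 2 `CCC(C)(C)Cc1c[nH]c(CCc2ccc(-c3ccncc3)cc2)n1` gives 101 nM, the highest of the three numbers and therefore the weakest inhibitor of the set. The two steps that touch it are large: a 14-fold higher number from compound 1 to compound 2 (1.14 log units; beyond the scatter) and a 13-fold lower number from compound 2 to compound 3 (1.13 log units; beyond the scatter). Both show that exchanging the aromatic ring at this position of the core of compound 2 moves the number well beyond the scatter, and in both cases compound 2 sits at the high end.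

Compound 4 `CCC(C)(C)Cc1c[nH]c(CCc2ccc(-n3cncn3)cc2)n1` carries the change (1H-1,2,4-triazol-1-yl in place of pyridin-4-yl on an aromatic carbon). Among the compounds with values here, no measured step places a five-membered ring at this position, so the measured steps bear on it only indirectly: they show that this site is sensitive to the ring attached there, and that compound 2 has room to fall. The expectation is therefore a lower number than compound 2 gives, though with wide uncertainty about how far. Compound 4 is expected to give about 30 nM, within a range from 8 nM to 150 nM. The expected step is a 3.4-fold lower number from compound 2 to compound 4 (0.53 log units; beyond the scatter).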

Compound 4, half-maximal inhibitory concentration: 340 nM
Estimate against measurement, compound 4: 11-fold (1.05 log units) below, outside the stated range (above it).
By their numbers in this assay, from the lowest: compounds 1 and 3 (each within the scatter of the next); then compound 2; then compound 4.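

In this assay the 1H-1,2,4-triazol-1-yl ring brings the first five-membered ring to this aromatic carbon, and the number rises rather than falls, with a 3.4-fold higher number from compound 2 to compound 4 (0.53 log units; beyond the scatter), so the pyridin-4-yl group, though the weakest of the three six-membered rings, still does better here than this ring. Measured against the two stronger six-membered rings the cost is much larger, with a 45-fold higher number from compound 3 to compound 4 (1.66 log units; beyond the scatter) and a 47-fold higher number from compound 1 to compound 4 (1.67 log units; beyond the scatter), which leaves compound 4 as the weakest inhibitor of the four and widens the spread of numbers that this single site can produce. This change alters ring size and the count of hetero atoms at once, so the compounds cannot separate the two, and no information is available here to explain the result.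

Still open, as far as these compounds go, is whether a five-membered ring with fewer ring nitrogens, such as pyrazol-1-yl or imidazol-1-yl, would give a number closer to those of the six-membered rings. From the compounds shown here alone, it also remains unknown whether an amine added to the 1H-1,2,4-triazol-1-yl ring would recover any of the lost inhibition.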